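A few compounds are considered here, and "the series" means these few. Any claim that something is new, unique, unknown or untested is made for them only; others in the source may bear on it.

Compound 1 `COc1cc(NC(C)CCCNC(=O)NNC(=O)Nc2ccc(C(F)(F)F)cc2)c2ncccc2c1`: 12000 nM
Compound 2 `COc1cc(NC(C)CCCNC(=O)NNC(=O)Nc2cccc(F)c2)c2ncccc2c1`: 9500 nM
Compound 3 `COc1cc(NC(C)CCCNC(=O)Nc2ccc(C(F)(F)F)cc2)c2ncccc2c1`: 22000 nM

All three values come from a functional assay on SW-620 cells (Homo sapiens) for inhibition, read by MTT assay, with a stated time of 72 h; on this read-out higher numbers stand for weaker inhibition and lower numbers for stronger inhibition. Compound 3 and compound 1 lie within the scatter of each other, while compound 3 stands apart from compound 2 beyond the scatter.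

The next entry is compound 4 `COc1cc(NC(C)CCCNC(=O)NNC(=O)Nc2cccc(Cl)c2)c2ncccc2c1`, which carries ((3-chlorophenyl)carbamoyl)amino in place of 4-(trifluoromethyl)phenyl on an amide-type nitrogen. Going by the values given here, two measured steps bear on this change. The closest is a 2.3-fold higher number from compound 2 to compound 3 (0.36 log units; beyond the scatter), a modest step that runs the same kind of exchange in the opposite direction, with the 3-fluorophenyl counterpart leaving. The other is a 1.3-fold lower number from compound 1 to compound 2 (0.10 log units; within the scatter), which changes only the aryl group and stays within the scatter. A modest step to a lower number is therefore expected in this assay. The expected change is a 2.4-fold lower number from compound 3 to compound 4 (0.39 log units; beyond the scatter). Compound 4 is estimated at 9000 nM, with an expected range of 4500 nM to 18000 nM.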

Compound 4, half-maximal inhibitory concentration: 25000 nM
For compound 4 the middle estimate is 2.8-fold (0.44 log units) below the measured one; measured number outside the range, above it.
By their numbers in this assay, from the lowest: compounds 2, 1, 3 and 4 (each within the scatter of the next, the first and the last beyond it).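

In this assay chloro in place of fluoro on an aromatic carbon is not a silent exchange: it gives a 2.6-fold higher number from compound 2 to compound 4 (0.42 log units; beyond the scatter) and shows that this single halogen position separates the two compounds. The ((3-chlorophenyl)carbamoyl)amino in place of 4-(trifluoromethyl)phenyl on an amide-type nitrogen gives a 1.1-fold higher number from compound 3 to compound 4 (0.06 log units; within the scatter) and no separation, while 3-chlorophenyl in place of 4-(trifluoromethyl)phenyl gives a 2.1-fold higher number from compound 1 to compound 4 (0.32 log units; beyond the scatter) and goes beyond the scatter, so with the 3-fluorophenyl exchanges as the comparison, the outcome of both changes depends on the halogen carried by compound 2 and compound 4. No measurement at hand accounts for these differences.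

Open, as far as these compounds go, is how an amine, a carboxylic acid or a methoxy group on the aryl ring would read at this position. Also open, from the compounds shown here alone, is whether a longer chain on the shared core would preserve the halogen dependence.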